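From 2-methyl-1,3-benzoxazol-5-yl to 1-benzothiophen-2-yl

The compounds below may be only part of what the source reports. "The series", "measured", "known", "first", "only" and "open" are said of these compounds alone.

In an ADME assay (liver) for metabolic stability, with Liver microsome (Homo sapiens) as the target, using microsomes and NADPH, with a stated time of 30 min, tested at 1 uM (a higher number here means faster removal of the compound, a lower number slower removal), compound 1 (`CCn1cc(-c2cc(C(O)(C(F)(F)F)C(F)(F)F)cnc2N2CCN(S(=O)(=O)c3ccc(N)nc3)CC2)cn1`) gives 20 mL.min-1.g-1 as a measured number. Compound 2 (`Cc1nc2cc(-c3cc(C(O)(C(F)(F)F)C(F)(F)F)cnc3N3CCN(S(=O)(=O)c4ccc(N)nc4)CC3)ccc2o1`) gives < 14 mL.min-1.g-1 as a limit of the assay and not a number. Its standing is therefore the limit of < 14 mL.min-1.g-1 in this assay, at which 1 of the 2 values shown sits, and nothing finer.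

Compound 3 (`Nc1ccc(S(=O)(=O)N2CCN(c3ncc(C(O)(C(F)(F)F)C(F)(F)F)cc3-c3cc4ccccc4s3)CC2)cn1`) carries 1-benzothiophen-2-yl in place of 2-methyl-1,3-benzoxazol-5-yl, ortho to a large group (1-benzothiophen-2-yl in place of 2-methyl-1,3-benzoxazol-5-yl on an aromatic carbon). Among the compounds with values here, only one measured step bears on this change, as it also exchanged a group on an aromatic carbon (an at least 1.4-fold lower number from compound 1 to compound 2 (0.15 log units; that floor lies within the scatter)). As far as these compounds go, its floor lies within the scatter, so no change beyond the scatter is expected in this assay here, and the direction remains open. The expected size is small (an at least 1.4-fold higher number from compound 2 to compound 3 (0.15 log units; that floor lies within the scatter)). Compound 3 is estimated at 20 mL.min-1.g-1 with an expected range of 10 mL.min-1.g-1 to 40 mL.min-1.g-1 in this measurement.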

Compound 3, intrinsic clearance in microsomes: < 14 mL.min-1.g-1
Compound 3 was reported as a limit; the forecaster's own chance of this, stated with the estimate: 25%; at least 1.4-fold (0.15 log units) between middle value and limit.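

With 1-benzothiophen-2-yl on the aromatic carbon ortho to a large group, compound 3 gives < 14 mL.min-1.g-1 in this assay, which is a limit of the assay and not a number. Measured against 1-ethyl-1H-pyrazol-4-yl, this group gives an at least 1.4-fold lower number from compound 1 to compound 3 (0.15 log units; that floor lies within the scatter), so the step shows a direction only as far as its floor, and that floor shows no change beyond the scatter. A second group at this position, with sulfur as its only hetero atom, now reaches the limit already seen with 2-methyl-1,3-benzoxazol-5-yl: the limit of < 14 mL.min-1.g-1 in this assay, at which 2 of the 3 values shown sit.

The step between the two limits cannot be read, so neither of these two groups can be placed ahead of the other. As far as these compounds go, it remains open how a phenyl ring, a morpholine or a primary amine at this position would read in this assay.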